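The compounds below may be only part of what the source reports. "The series", "measured", "known", "first", "only" and "open" are said of these compounds alone.

For the measured compounds named here, compound 2 `Nc1cccc(C(=O)/C=C/c2ccc3c(c2)B(O)OC3)c1` stands at the higher of the two numbers so far in a functional assay on MDA-MB-231 cells (Homo sapiens) for cytotoxicity, read by MTT assay, with a stated time of 48 h (a lower number here means a stronger inhibitor, a higher number a weaker inhibitor), giving 3200 nM. Its nearest neighbour, compound 1 `O=C(/C=C/c1ccc2c(c1)B(O)OC2)c1ccccc1`, gives 2300 nM in this assay , and the step of a 1.4-fold higher number from compound 1 to compound 2 (0.14 log units; within the scatter) falls within the scatter. Compound 3 `COCOc1cccc(C(=O)/C=C/c2ccc3c(c2)B(O)OC3)c1` carries methoxymethoxy in place of amino on an aromatic carbon. Going by the values given here, the only measured step bearing on this carbon is a 1.4-fold higher number from compound 1 to compound 2 (0.14 log units; within the scatter), and since that one stayed within the scatter, the expected step in this assay is a 1.1-fold lower number from compound 2 to compound 3 (0.03 log units; within the scatter), none beyond the scatter. Compound 3 is therefore estimated at 3000 nM, in the range 1200 nM to 8000 nM.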

Compound 3, half-maximal inhibitory concentration: 4500 nM
The estimate for compound 3 lay 1.5-fold (0.18 log units) below the measured number; measured number inside the range.
By their numbers in this assay, from the lowest: compounds 1, 2 and 3 (each within the scatter of the next).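

Replacing amino with methoxymethoxy on this aromatic carbon gives a 1.4-fold higher number from compound 2 to compound 3 (0.15 log units; within the scatter) in this assay, so a group with 4 heavy atoms and 0 hydrogen-bond donors is accommodated here without a step beyond the scatter. Set against hydrogen, the same group gives a 2.0-fold higher number from compound 1 to compound 3 (0.29 log units; within the scatter) and also stays within the scatter. No measurement offered here explains these numbers.

On these data alone, whether a carboxylic acid or a longer alkoxy chain on this carbon would move the number beyond the scatter remains open. Also open, as far as these compounds go, is how methoxymethoxy would read on another carbon of this ring.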